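Chloro for fluoro on the pendant phenyl of compound 2

The compounds below may be only part of what the source reports. "The series", "measured", "known", "first", "only" and "open" are said of these compounds alone.

Compound 2 `O=C(Nc1nc2ccc(F)cc2s1)c1cn(-c2ccccc2)nc1-c1ccc(F)cc1` gives 16700 nM in an ADME assay on HEK-293T cells (Homo sapiens) for cytotoxicity, read by MTT assay, with a stated time of 72 h; on this read-out higher numbers stand for weaker inhibition and lower numbers for stronger inhibition; compound 1 `O=C(Nc1nc2ccccc2s1)c1cn(-c2ccccc2)nc1-c1ccc(F)cc1` gives 33400 nM, and the step of a 2.0-fold lower number from compound 1 to compound 2 (0.30 log units; within the scatter) lies within the scatter, so the two numbers are not separated. Compound 3 `O=C(Nc1nc2ccc(F)cc2s1)c1cn(-c2ccccc2)nc1-c1ccc(Cl)cc1` differs from compound 2 by chloro in place of fluoro on an aromatic carbon. For the measured compounds named here, no measured step touches this ring; the only step available, from the unsubstituted to the fluorinated fused ring, stayed within the scatter. A step of a 1.1-fold lower number from compound 2 to compound 3 (0.05 log units; within the scatter) is therefore expected for compound 3, with no change beyond the scatter. Compound 3 is estimated at 15000 nM, range 6000 nM to 40000 nM.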

Compound 3, half-maximal inhibitory concentration: > 50000 nM
Compound 3 ended at the assay's limit; the forecaster's own chance of this, stated with the estimate: 10%; middle value at least 3.3-fold (0.52 log units) away from the limit.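

In this assay, for the compounds shown here, the change to 4-chlorophenyl gives an at least 2.9-fold higher number from compound 2 to compound 3 (0.47 log units; beyond the scatter), the first step beyond the scatter, and it shows that this position can move the read-out even through a single halogen exchange. Compound 3 gives > 50000 nM, which is a limit of the assay and not a number: the limit of > 50000 nM in this assay, at which 1 of the 3 values shown sits.

On these data alone, the real size of the step remains open, as does whether it is specific to chloro. Bromo, methyl or an amine at this position could show whether other groups move the number in the same way.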